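Piperidine Amide in Place of Piperazine on the Shared Core

This account rests on a few compounds, and the source may have more. Where it says the series, first, only, none or still open, it means among the compounds named here.

Among the compounds with values here, compound 1 `Nc1sc(-c2ccc(Cl)cc2)c(-c2ccc(Cl)cc2)c1C(=O)N1CCNCC1` gives 1020 nM in a functional assay on A549 cells (Homo sapiens) for inhibition, read by sulforhodamine B assay, with a stated time of 72 h (a lower number here means a stronger inhibitor, a higher number a weaker inhibitor), the lowest of the two numbers measured so far; its nearest neighbour is compound 2 `Nc1sc(-c2ccc(Cl)cc2)c(-c2ccc(Cl)cc2)c1C(=O)Nc1ccccc1`, which gives 25000 nM. Within the data shown here, the only measured step, a 25-fold higher number from compound 1 to compound 2 (1.39 log units; beyond the scatter), concerns a different replacement on the same carbonyl carbon and so bears only loosely on compound 3 `Nc1sc(-c2ccc(Cl)cc2)c(-c2ccc(Cl)cc2)c1C(=O)N1CCCCC1`. Here the change is piperidin-1-yl in place of piperazin-1-yl on a carbonyl carbon. Among the measured compounds shown here, no measured step covers this change, so only a small step in this assay is expected, toward a somewhat higher number. Compound 3 is therefore estimated at 2500 nM, between 600 nM and 10000 nM. For compound 3 the expected step is a 2.5-fold higher number from compound 1 to compound 3 (0.39 log units; beyond the scatter).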

Compound 3, half-maximal inhibitory concentration: 4620 nM
For compound 3 the middle estimate is 1.8-fold (0.27 log units) below the measured one; the measured number falls inside the stated range.
By their numbers in this assay, from the lowest: compound 1; then compound 3; then compound 2.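

In this assay, the change on the carbonyl carbon gives a 4.5-fold higher number from compound 1 to compound 3 (0.66 log units; beyond the scatter) even though piperazin-1-yl and piperidin-1-yl are both six-membered non-aromatic rings, so this position responds to a change within the ring itself. Keeping a saturated ring while replacing anilino gives a 5.4-fold lower number from compound 2 to compound 3 (0.73 log units; beyond the scatter) and places compound 3 on the printed scale with the piperazine amide of compound 1 still lowest. No measurement shown here explains either step.

Going by these compounds, it remains open where a morpholin-4-yl or a 4-methylpiperazin-1-yl group on the same carbonyl carbon would fall. On these data alone, it also remains open whether this order holds on a different core.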